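A few compounds are considered here, and "the series" means these few. Any claim that something is new, unique, unknown or untested is made for them only; others in the source may bear on it.

Going by the values given here, compound 1 `COc1ccc(NC(=O)C2(C(=O)Nc3ccc(Nc4ncc5cc(C(=O)N(C)C)n(C6CCCC6)c5n4)cc3)CC2)cc1` is one of two compounds measured in a functional assay on A549 cells (Homo sapiens) for inhibition, read by CCK-8 assay, with a stated time of 72 h, tested at 10 uM; a higher number here means more inhibition of growth at the concentration tested, a lower number less inhibition of growth. In this assay compound 1 gives 78.5%, the lower of the two numbers. Compound 2 `COC(=O)c1cccc(NC(=O)C2(C(=O)Nc3ccc(Nc4ncc5cc(C(=O)N(C)C)n(C6CCCC6)c5n4)cc3)CC2)c1` carries 3-(methoxycarbonyl)phenyl in place of 4-methoxyphenyl on an amide-type nitrogen, and in this assay compound 2 gives 91%; the step of a number 12.5 percentage points higher from compound 1 to compound 2 (beyond the scatter) is beyond the scatter but modest. Compound 3 `CN(C)C(=O)c1cc2cnc(Nc3ccc(NC(=O)C4(C(=O)Nc5ccccc5)CC4)cc3)nc2n1C1CCCC1` has not yet been measured. It differs from compound 1 by hydrogen in place of methoxy on an aromatic carbon. Among the compounds with values here, the single measured step concerns a different exchange of that group, so it bears on compound 3 only loosely: it shows that the group on the amide-type nitrogen can be changed without loss of inhibition. A step of about the size of a number 1.5 percentage points higher from compound 1 to compound 3 (within the scatter) is therefore expected, a movement that stays within the scatter. Compound 3 is estimated to reach 80% in this assay, with a range from 65% to 92%.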

Compound 3, percent growth inhibition at one concentration: 88.8%
Estimate against measurement, compound 3: 8.8 percentage points below, and the stated range covers the measured number.
By their numbers in this assay, from the lowest: compound 1; then compounds 3 and 2 (each within the scatter of the next).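

Taking away the methoxy is not neutral at this place: a number 10.3 percentage points higher from compound 1 to compound 3 (beyond the scatter) in this assay, so the plain phenyl needs no added group on this ring to reach a high number. With a number 2.2 percentage points lower from compound 2 to compound 3 (within the scatter), the plain phenyl and the 3-(methoxycarbonyl)phenyl cannot be told apart. The earlier step therefore need not reflect anything gained from methoxycarbonyl, since among these three compounds only compound 1, the one carrying methoxy, stands lower.

Still open, as far as these compounds go, is whether another group on this aromatic carbon, such as fluorine, an amine or a carboxylic acid, would behave like methoxy or like hydrogen. No measurement shown here explains what separates methoxy from hydrogen at this place.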